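The compounds below may be only part of what the source reports. "The series", "measured", "known", "first", "only" and "open" are said of these compounds alone.

In a functional assay on the whole organism for inhibition, with Mus musculus as the target (a lower number here means that less compound is needed, a higher number that more compound is needed for the effect), compound 1 (`CN1Cc2c(N)cccc2C(c2ccc(Cl)cc2)C1`) gives 1.1 mg/kg and compound 2 (`CC(C)c1ccc(C2CN(C)Cc3c(N)cccc32)cc1`) gives 68 mg/kg. Compound 3 (`CCNC(=O)Nc1cccc2c1CN(C)CC2c1ccccc1`) gives 54 mg/kg, which lies within the scatter of compound 2 and beyond the scatter of compound 1, on the side of the higher numbers.

The next structure is compound 4 (`CCNCCC(=O)Nc1cccc2c1CN(C)CC2c1ccccc1`). It carries 2-(ethylamino)ethyl in place of the ethylamino of compound 3, on a carbonyl carbon whose other neighbour is an amide-type nitrogen: 2-(ethylamino)ethyl in place of ethylamino on a carbonyl carbon. Cut one bond further out, this reads (ethylcarbamoyl)amino to ((2-(ethylamino)ethyl)carbonyl)amino.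

Within the data shown here, the only measured step is a 62-fold higher number from compound 1 to compound 2 (1.79 log units; beyond the scatter). It came with isopropyl in place of chloro on an aromatic carbon, so it lies at a different place and does not test this change. It shows only that one substitution on this series can move this assay a long way, which is reason to keep the range wide. Among the measured compounds shown here, no measured pair speaks to direction, so no step beyond the scatter is expected, and the expected step is a 1.4-fold lower number from compound 3 to compound 4 (0.13 log units; within the scatter). Compound 4 is estimated at 40 mg/kg, with an expected range of 10 mg/kg to 130 mg/kg.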

Compound 4, dose for half-maximal effect: > 160 mg/kg
Compound 4: only a limit was reported; the forecaster's own chance of this, stated with the estimate: 10%; middle value at least 4.0-fold (0.60 log units) from the limit.
By their numbers in this assay, from the lowest: compound 1; then compounds 3 and 2 (each within the scatter of the next). At a limit, above all of these: compound 4.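

In this assay, compound 4 gives > 160 mg/kg, which is a limit and not a number. Among these compounds, the earlier step changed an aromatic carbon, whereas this one gives the series its only reading on the carbonyl carbon whose other neighbour is an amide-type nitrogen: 2-(ethylamino)ethyl in place of ethylamino gives an at least 2.9-fold higher number from compound 3 to compound 4 (0.47 log units; beyond the scatter), so this position is not indifferent to the change and the number moves upward, by an amount that remains unknown. The reading rests on a single censored result, so it fixes a direction and a minimum step, not an end value: the limit of > 160 mg/kg in this assay, at which 1 of the 4 values shown sits.

The compounds shown leave open whether the step follows from the greater length of the chain or from the placement of its ethylamino nitrogen, as the one change alters both together. A plain butyl chain on the same carbonyl carbon would address the first of these, while a longer chain ending in dimethylamino or a carboxylic acid would show how far this position tolerates other ends.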